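Allyl for ethyl on the ring nitrogen of compound 2

The source may report more compounds than this note shows. Statements on the series, on what has been measured and on what is new or still open speak of the compounds shown alone.

Measured compounds:
- compound 1, `CCCN(c1nc(-c2ccc(Br)cc2C)n(C)n1)C(C1CC1)C1CC1`: 10 nM
- compound 2, `CCCN(c1nc(-c2c(C)cc(C)cc2C)n(CC)n1)C(C1CC1)C1CC1`: 310 nM

In an assay on CHO cells for binding affinity to corticotropin-releasing factor receptor 1 (Homo sapiens) (a lower number here means a stronger inhibitor, a higher number a weaker inhibitor), compound 1 gives 10 nM. In this assay compound 2 gives 310 nM, the highest of the two numbers; compound 1 stands well below it, and that gap lies beyond the usual scatter. Among the measured compounds shown here, compound 1 and compound 2 differ in more than one place, so no single step between them can be read from the numbers.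

Compound 3, `C=CCn1nc(N(CCC)C(C2CC2)C2CC2)nc1-c1c(C)cc(C)cc1C`, is not yet measured. It differs from compound 2 in one place: vinyl in place of methyl on a saturated chain carbon bound to an aromatic nitrogen. Cut one bond further out, the same change reads ethyl to allyl on the aromatic nitrogen; the rest of the molecule, including the ring with three methyl groups, is unchanged.

For the measured compounds named here, no step of this kind is available among the measured compounds. Exchanging a small saturated chain for a short unsaturated one is expected to move this assay little, if at all beyond the scatter, in either direction; the step from compound 2 to compound 3 is estimated at a 1.2-fold lower number from compound 2 to compound 3 (0.09 log units; within the scatter). Compound 3 is expected to give about 250 nM, within 80 nM to 800 nM.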

Compound 3, inhibition constant: 2200 nM
Beside the measured number, compound 3's estimate is 8.8-fold (0.94 log units) below it, outside the stated range (above it).
By their numbers in this assay, from the lowest: compound 1; then compound 2; then compound 3.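

In this assay the aromatic nitrogen of this series is not indifferent to the group it carries: ethyl to allyl there gives a 7.1-fold higher number from compound 2 to compound 3 (0.85 log units; beyond the scatter) with the rest of the molecule unchanged. Among the compounds shown here, compound 1 and compound 2 differ in more than one place, so this is the first step that can be read at a single position, and it shows that vinyl in place of methyl on this saturated chain carbon is enough to move the number beyond the scatter, towards a weaker inhibitor. Nothing in the data at hand accounts for the size or direction of this step.

Still open, on these data alone, is whether the double bond or the longer chain goes with the weaker binding, and a propyl chain on this nitrogen would set the two apart. Also open, as far as these compounds go, are how a cyclopropylmethyl or methoxyethyl group behaves at this position, and whether ethyl to allyl gives a step of similar size when the rest of the molecule is that of compound 1.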